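The source may hold more compounds than are shown below. What is called first, only, known or untested is meant among the compounds shown, and "the series" means these compounds.

Working notes on the series, read in a functional assay on HeLa cells (Homo sapiens) for inhibition, read by trypan blue exclusion, with a stated time of 72 h; a higher number here means a weaker inhibitor of growth, a lower number a stronger inhibitor of growth. Compound 1 `CC/C(=C(/c1ccccc1)c1ccc(NC(=O)C(C)C)cc1)c1ccccc1` gives 28100 nM, and compound 2 `CC/C(=C(\c1ccc(NC(=O)C(C)C)cc1)c1ccc(OC)cc1)c1ccccc1` gives 10100 nM. The measured step between them, a 2.8-fold lower number from compound 1 to compound 2 (0.44 log units; beyond the scatter), is modest, with methoxy in place of hydrogen on an aromatic carbon. Compound 3 `CC/C(=C(\c1ccc(O)cc1)c1ccc(NC(=O)C(C)C)cc1)c1ccccc1` gives 9900 nM, which is level with compound 2 within the scatter and a lower number than that of compound 1.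

The next comparison is with compound 4 `CC/C(=C(/c1ccc(O)cc1)c1ccc(NC(=O)C(C)C)cc1)c1ccccc1`. The structural change is the two compounds have the same atoms and bonds and differ only in configuration as drawn: 1 of 1 stereo elements differ; a double bond is drawn E in compound 3 and Z in compound 4. Going by the values given here, no measured step is a change of double-bond configuration alone, so the data give no direct size for this one. The step of a 2.8-fold lower number from compound 1 to compound 2 (0.44 log units; beyond the scatter) is a different kind of change and bears on it only as a measure of how far one substitution moves the numbers here. Compound 2, at 10100 nM, is drawn with the same double-bond configuration as compound 4, and its value sits level with that of compound 3. No direction can be argued from this, so no change beyond the scatter is expected, and the estimated shift is a 1.0-fold higher number from compound 3 to compound 4 (0.00 log units; within the scatter). The estimate for compound 4 is 10000 nM, with an expected range from 4500 nM to 22000 nM.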

Compound 4, concentration for 50% growth inhibition: 9900 nM
Compound 4: the middle estimate sits 1.0-fold (0.00 log units) above what was measured; the measured number falls inside the stated range.
By their numbers in this assay, from the lowest: compounds 3, 4 and 2 (each within the scatter of the next); then compound 1.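

In this assay, going by these compounds alone, swapping the double-bond configuration leaves the number in place, with no change at the digits printed from compound 3 to compound 4 (within the scatter), and this is the first direct reading of that change, free of any other structural difference: the fact that compounds 3 and 4 differ only in the configuration as drawn. Among compounds drawn with the same configuration, the oxygen substituent can carry a methyl or a hydrogen without a change beyond the scatter, with a 1.0-fold lower number from compound 2 to compound 4 (0.01 log units; within the scatter). The hydroxy group itself gives a modest step, with a 2.8-fold lower number from compound 1 to compound 4 (0.45 log units; beyond the scatter), which places it alongside the methoxy step, a 2.8-fold lower number from compound 1 to compound 2 (0.44 log units; beyond the scatter), as a second oxygen substituent that lowers the number relative to the unsubstituted compound 1.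

As far as these compounds go, whether the double-bond configuration stays equally silent with methoxy, or with an amine or a carboxylic acid on that aromatic carbon, remains open. Also open, from the compounds shown here alone, is whether this holds when the isobutyramide side is changed, for instance to a longer chain on the carbonyl, and whether any such group would move the numbers further than the modest steps seen here.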